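Sulfonamide aryl variation in the shared core series

The source may report more compounds than this note shows. Statements on the series, on what has been measured and on what is new or still open speak of the compounds shown alone.

Within the data shown here, compound 1 `O=C1NCCN1c1ccc(S(=O)(=O)Nc2ccc(F)cc2)cc1` gives 230 nM in a functional assay on M21 cells (Homo sapiens) for antiproliferative activity, read by sulforhodamine B assay, with a stated time of 48 h (a lower number here means a stronger inhibitor, a higher number a weaker inhibitor), the highest of the three numbers measured so far. Compound 2 `O=C1NCCN1c1ccc(S(=O)(=O)Nc2ccc(F)c(F)c2)cc1` gives 220 nM in this assay, and the step of a 1.0-fold lower number from compound 1 to compound 2 (0.02 log units; within the scatter) lies within the scatter. Among the measured compounds shown here, compound 3 `CCc1cccc(NS(=O)(=O)c2ccc(N3CCNC3=O)cc2)c1` gives 82 nM in this assay; the step of a 2.8-fold lower number from compound 1 to compound 3 (0.45 log units; beyond the scatter) is the only change beyond the scatter, and a 2.7-fold lower number from compound 2 to compound 3 (0.43 log units; beyond the scatter) matches it in size.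

Compound 4 `COc1ccc(NS(=O)(=O)c2ccc(N3CCNC3=O)cc2)cc1` differs from compound 1 by methoxy in place of fluoro on an aromatic carbon. For the measured compounds named here, no measured step exchanges this group alone. The nearest guide is a 1.0-fold lower number from compound 1 to compound 2 (0.02 log units; within the scatter), where a fluoro entered without moving the number beyond the scatter, while a 2.8-fold lower number from compound 1 to compound 3 (0.45 log units; beyond the scatter) shows that a different aryl on the sulfonamide nitrogen can lower the number modestly. A step within the scatter, or at most a small decrease, is therefore expected in this assay. For compound 4 the expected value is 180 nM, with a range from 80 nM to 400 nM. This corresponds to an expected step of a 1.3-fold lower number from compound 1 to compound 4 (0.11 log units; within the scatter).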

Compound 4, half-maximal inhibitory concentration: 580 nM
Estimate against measurement, compound 4: 3.2-fold (0.51 log units) below; measured number above the stated range.
By their numbers in this assay, from the lowest: compound 3; then compounds 2 and 1 (each within the scatter of the next); then compound 4.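

Methoxy in place of fluoro on the aromatic carbon para to a large group raises the number in this assay (a 2.5-fold higher number from compound 1 to compound 4 (0.40 log units; beyond the scatter)), the first change of the sulfonamide aryl group shown to do so. Compound 4 also stands apart from the other two aryl groups (a 2.6-fold higher number from compound 2 to compound 4 (0.42 log units; beyond the scatter); a 7.1-fold higher number from compound 3 to compound 4 (0.85 log units; beyond the scatter)), and its steps to all three are beyond the scatter, making it the weakest of the four compounds. Thus, the 4-fluorophenyl to 4-methoxyphenyl change is not neutral in this series, although nothing available explains the rise.

Still open, going by these compounds, is whether the rise follows the oxygen of the methoxy or the larger group as such. An ethyl chain, a hydroxyl or an amine at this same place would help separate these readings.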